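Aryl change on the nitrogen of compound 3

The compounds below may be only part of what the source reports. "The series", "measured", "known", "first", "only" and "open" are said of these compounds alone.

Among the compounds with values here, in a functional assay on MCF7 cells (Homo sapiens) for cytotoxicity, read by MTT assay, with a stated time of 72 h (on this read-out lower numbers stand for stronger inhibition and higher numbers for weaker inhibition), compound 3 `O=C(Nc1ccc(Oc2ncnc3[nH]ccc23)c(F)c1)c1cc2cccnc2n(-c2ccccc2)c1=O` reads 45000 nM and compound 2 `Cn1ccc2c(Oc3ccc(NC(=O)c4cc5cccnc5n(-c5ccccc5)c4=O)cc3F)ncnc21` reads 73400 nM as the only two numbers, and they lie within the scatter of each other. Compound 1 `Cn1ccc2c(Oc3ccc(NC(=O)c4cc5cccnc5n(-c5ccc(C(F)(F)F)c(Cl)c5)c4=O)cc3)ncnc21` also carries chlorine and trifluoromethyl on the ring at the aromatic nitrogen, but it differs from compound 3 elsewhere too. Within the data shown here, compound 1 is reported as "not active" (no number reported) without a number, so it gives no size of step. Compound 4 `O=C(Nc1ccc(Oc2ncnc3[nH]ccc23)c(F)c1)c1cc2cccnc2n(-c2ccc(C(F)(F)F)cc2Cl)c1=O` is still unmeasured, and its change is 2-chloro-4-(trifluoromethyl)phenyl in place of phenyl on an aromatic nitrogen at that same place. Among the measured compounds shown here, the one measured step, a 1.6-fold lower number from compound 2 to compound 3 (0.21 log units; within the scatter) for hydrogen in place of methyl, lies within the scatter and sits at a different place, so it bears only indirectly. The expected outcome is an estimated 1.3-fold lower number from compound 3 to compound 4 (0.11 log units; within the scatter) with no shift beyond the scatter, though a result without a number remains possible. For compound 4 in this assay the estimated value is 35000 nM with an expected range from 9000 nM to 100000 nM as the likely span.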

Compound 4, half-maximal inhibitory concentration: 214000 nM
Compound 4: middle estimate off by 6.1-fold (0.79 log units), on the low side; the measured number lies above the stated range.
By their numbers in this assay, from the lowest: compounds 3 and 2 (each within the scatter of the next); then compound 4.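

In this assay, within the data shown here, the ring on the aromatic nitrogen gives the first step that is printed as beyond the scatter: a 4.8-fold higher number from compound 3 to compound 4 (0.68 log units; beyond the scatter) for 2-chloro-4-(trifluoromethyl)phenyl in place of phenyl. Among these compounds, this position therefore responds to substitution, and here the change goes with weaker inhibition, whereas the only earlier step, a 1.6-fold lower number from compound 2 to compound 3 (0.21 log units; within the scatter) at a different place, stayed within the scatter. Nothing measured here accounts for the size or direction of this step.

Chlorine and trifluoromethyl enter together, so their separate contributions stay unresolved, and a ring with either group alone would be needed to divide the step. Also open, going by these compounds, are how an amine or a carboxylic acid on this ring would read, and whether the step holds with methyl in place of hydrogen on the other aromatic nitrogen.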